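Cyclohexylmethoxy in place of 3-methylbenzyloxy on the acetyl-bearing core

The source may report more compounds than this note shows. Statements on the series, on what has been measured and on what is new or still open speak of the compounds shown alone.

In an assay on isolated protein for antagonist activity at Bile acid receptor (Homo sapiens), read by HTRF, with a stated time of 30 min (on this read-out higher numbers stand for weaker inhibition and lower numbers for stronger inhibition), compound 1 `CCCCc1cc(CC)c(O)cc1OCCCCCC(C)(C)c1nnn[nH]1` gives 8700 nM, compound 2 `CCc1cc(C(C)=O)c(OCc2ccccc2)cc1OCCCCCC(C)(C)c1nnn[nH]1` gives 1100 nM, and compound 3 `CCc1cc(C(C)=O)c(OCc2cccc(C)c2)cc1OCCCCCC(C)(C)c1nnn[nH]1` gives 1200 nM. Compound 3 stands second highest of the three numbers: its nearest neighbour is compound 2, within the scatter, and its furthest is compound 1, beyond the scatter. Among the measured compounds shown here, the single one-place step measured so far, a 1.1-fold higher number from compound 2 to compound 3 (0.04 log units; within the scatter), stays within the scatter.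

Compound 4 `CCc1cc(C(C)=O)c(OCC2CCCCC2)cc1OCCCCCC(C)(C)c1nnn[nH]1` has not been measured. It differs from compound 3 by cyclohexyl in place of 3-methylphenyl on a saturated chain carbon bound to an oxygen on an aromatic ring. For the measured compounds named here, only the step from compound 2 to compound 3 touches this part of the molecule, and it was small; no measured step exchanges an aromatic ring for a saturated one, so the data give no direction for this change. The expected step is a 1.1-fold higher number from compound 3 to compound 4 (0.03 log units; within the scatter), not beyond the scatter. Compound 4 is therefore estimated to give about 1300 nM in this assay, with a range from 500 nM to 4000 nM.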

Compound 4, half-maximal inhibitory concentration: 2900 nM
Beside the measured number, compound 4's estimate is 2.2-fold (0.35 log units) below it, and the stated range covers the measured number.
By their numbers in this assay, from the lowest: compounds 2 and 3 (each within the scatter of the next); then compound 4; then compound 1.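

Methyl on the aromatic ring left the number within the scatter in this assay (a 1.1-fold higher number from compound 2 to compound 3 (0.04 log units; within the scatter)), whereas the saturated ring moves it beyond the scatter: a 2.4-fold higher number from compound 3 to compound 4 (0.38 log units; beyond the scatter) and a 2.6-fold higher number from compound 2 to compound 4 (0.42 log units; beyond the scatter) on the same shared core. On a saturated chain carbon bound to an oxygen on an aromatic ring, cyclohexyl therefore gives a higher number, meaning weaker inhibition, than either 3-methylphenyl or phenyl, and both steps are modest. Nothing available explains this difference.

With cyclohexyl as the only non-aromatic ring here, the compounds do not show whether other saturated rings would follow it. They also leave open how a longer chain or an amine in place of the cyclohexyl would read.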